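Three ring-isomeric quinone amino acids all sit at one limit

This account rests on a few compounds, and the source may have more. Where it says the series, first, only, none or still open, it means among the compounds named here.

Measured so far:
compound 1 `C=C1[C@H](C)CCC[C@]1(C)CC/C(C)=C/CC1=C(O)C(=O)C=C(N[C@H](CO)C(=O)O)C1=O`: > 10 ug/mL
compound 2 `CC1=CCC[C@](C)(CC/C(C)=C/CC2=C(O)C(=O)C=C(N[C@H](CO)C(=O)O)C2=O)[C@@H]1C`: > 10 ug/mL
compound 3 `C=C1[C@H](C)CCC[C@]1(C)CC/C(C)=C/CC1=C(O)C(=O)C=C(N[C@H](C(=O)O)[C@H](C)O)C1=O`: > 10 ug/mL

The three compounds share a quinone core bearing an amino acid and a terpenoid chain. In an ADME assay on KB cells (Homo sapiens) for cytotoxicity, with a stated time of 48 h (a lower number here means a stronger inhibitor, a higher number a weaker inhibitor), compound 1 reaches only the limit of the assay and not a number. Compound 2, in this assay, likewise gives only a limit. Compound 3 also stops at a limit in this assay. Compound 2 differs from compound 1 by a group of 9 heavy atoms (9 carbon; one six-membered non-aromatic ring of carbon only) in place of a group of 9 heavy atoms (9 carbon; one six-membered non-aromatic ring of carbon only), on a saturated chain carbon, two bonds along the chain from a double-bonded chain carbon, and the step that the two limits leave unreadable from compound 1 to compound 2 cannot be sized. Compound 3 differs from compound 1 by 1-carboxy-2-hydroxypropyl in place of 1-carboxy-2-hydroxyethyl on an amine nitrogen, and the step that the two limits leave unreadable from compound 1 to compound 3 is equally unreadable, since (the limit of > 10 ug/mL in this assay, at which 3 of the 3 values shown sit).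

Compound 4 `CC1=CCC[C@](C)(CC/C(C)=C/CC2=C(O)C(=O)C=C(N[C@H](C(=O)O)[C@H](C)O)C2=O)[C@@H]1C` is not yet measured. It stands to compound 3 as compound 2 stands to compound 1: the same change, (a group of 9 heavy atoms (9 carbon; one six-membered non-aromatic ring of carbon only) in place of a group of 9 heavy atoms (9 carbon; one six-membered non-aromatic ring of carbon only), on a saturated chain carbon, two bonds along the chain from a double-bonded chain carbon). Since all three shown values rest on (the limit of > 10 ug/mL in this assay, at which 3 of the 3 values shown sit), the step that the limit leaves unreadable from compound 3 to compound 4 is expected to be small or itself unreadable. Compound 4 is therefore expected to give 15 ug/mL in this assay, most likely between 8 ug/mL and 50 ug/mL, and probably again as a limit.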

Compound 4, half-maximal inhibitory concentration: > 10 ug/mL
Compound 4: only a limit was reported; the forecaster's own chance of this, stated with the estimate: 85%; the middle value does not contradict the limit.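

In this assay, for the compounds shown here, compound 4 gives only a limit, so no step from compound 3 or compound 2 to compound 4 can be read, and the comparison stays without a size: the limit of > 10 ug/mL in this assay, at which 4 of the 4 values shown sit. The compounds shown leave open whether any of compound 1, compound 2, compound 3 and compound 4 differs from the others in this assay.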